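The source may report more compounds than this note shows. Statements on the series, on what has been measured and on what is new or still open speak of the compounds shown alone.

Working notes on the series. Going by the values given here, compound 2 `CCC(C)OC(=O)/C=C(C)/C=C/CC(C)CCCC(C)(C)OC` gives 6.49 in a physicochemical assay for lipophilicity (on this read-out higher numbers stand for higher lipophilicity and lower numbers for lower lipophilicity), the lowest of the three numbers measured so far. Among the compounds with values here, compound 1 `CCC(C)OC(=O)/C=C(C)/C=C/CC(C)CCCC(C)C` gives 7.69; the step of a number 1.20 log units lower from compound 1 to compound 2 (beyond the scatter) is the only single-place change measured. Compound 3 `CSC(C)(C)CCCC(C)C/C=C/C(C)=C/C(=O)OC(C)C` gives 6.77, a number within the scatter of compound 2, though the two differ in more than one place.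

Compound 4 `COC(C)(C)CCCC(C)C/C=C/C(C)=C/C(=O)SC(C)C` differs from compound 2 by isopropylsulfanyl in place of sec-butoxy on a carbonyl carbon. Within the data shown here, no measured step bears directly on this exchange at the carbonyl carbon, so the expectation rests on the shared core alone and is weak. A step of a number 0.31 log units higher from compound 2 to compound 4 (beyond the scatter) of small size is expected, within or barely beyond the scatter. For compound 4 the estimate in this assay is 6.8, expected between 6.3 and 7.3.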

Compound 4, partition coefficient: 7.19
For compound 4 the middle estimate is 0.39 log units below the measured one; measured number inside the range.
By their numbers in this assay, from the lowest: compounds 2 and 3 (each within the scatter of the next); then compound 4; then compound 1.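

The exchange of sec-butoxy for isopropylsulfanyl on a carbonyl carbon gives a number 0.70 log units higher from compound 2 to compound 4 (beyond the scatter) in this assay. Going by these compounds alone, this is the first measured step at this position, and it shows that the read-out responds here beyond the scatter, in the opposite direction to the only earlier step, a number 1.20 log units lower from compound 1 to compound 2 (beyond the scatter), which lies on the saturated chain. Nothing available explains the size or direction of the step.

The exchange alters both the atom bound to the carbonyl carbon and the attached chain, and the two contributions cannot be separated. As far as these compounds go, how isopropylamino or a longer chain on the sulfur would read at this carbonyl carbon remains open.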